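Working notes: removing the side chain of compound 2

The source may hold more compounds than are shown below. What is called first, only, known or untested is meant among the compounds shown, and "the series" means these compounds.

- compound 1 `C[C@H](NC(=O)Cn1ccc(=O)[nH]c1=O)C(=O)N[C@@H](CC(=O)O)C(=O)O`: > 252000 nM (a limit)
- compound 2 `C[C@H](NC(=O)Cn1ccc(=O)[nH]c1=O)C(=O)N[C@@H](CCC(=O)O)C(=O)O`: 210000 nM
- compound 3 `C[C@H](NC(=O)Cn1ccc(=O)[nH]c1=O)C(=O)NCC(=O)O`: not yet measured

Going by the values given here, in a functional assay on L6 cells (Rattus norvegicus) for cytotoxicity (a lower number here means a stronger inhibitor, a higher number a weaker inhibitor), compound 2 gives 210000 nM, the only actual number so far. Compound 1 sits at a limit, not a number: the limit of > 252000 nM in this assay, at which 1 of the 2 values shown sits.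

Compound 3 carries hydrogen in place of 2-carboxyethyl on a saturated chain carbon bound to an amide-type nitrogen and a carbonyl carbon.

Compound 2 has one measured step bearing on this, an at least 1.2-fold lower number from compound 1 to compound 2 (0.07 log units; that floor lies within the scatter), and its floor lies within the scatter. No change beyond the scatter is therefore expected in this assay, and no direction is firm. The estimated 1.2-fold higher number from compound 2 to compound 3 (0.08 log units; within the scatter) is small. For compound 3 the expected value is 250000 nM, with an estimated range of 130000 nM to 400000 nM.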

Compound 3, half-maximal inhibitory concentration: > 301000 nM
Compound 3 was reported as a limit; the forecaster's own chance of this, stated with the estimate: 55%; middle value at least 1.2-fold (0.08 log units) from the limit.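

In this assay, compound 3 is reported as a limit, not a number: the limit of > 301000 nM in this assay, at which 1 of the 3 values shown sits.

Hydrogen in place of 2-carboxyethyl gives an at least 1.4-fold higher number from compound 2 to compound 3 (0.15 log units; that floor lies within the scatter), so removing the side chain shows no firm shift at this position, although the true step may be larger. The step between compound 1 and compound 3 cannot be read, as both values are limits.

From the compounds shown here alone, whether any group on this saturated chain carbon can lower the number beyond the scatter remains open. An aminobutyl chain, ending in an amine, or a benzyl group would test this.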